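This account rests on a few compounds, and the source may have more. Where it says the series, first, only, none or still open, it means among the compounds named here.

In a functional assay on HeLa cells (Homo sapiens) for antiproliferative activity, read by MTT assay, with a stated time of 72 h (a higher number here means a weaker inhibitor, a lower number a stronger inhibitor), compound 1 `COc1ncc(-c2ccc3c(c2)NC(=O)CO3)cc1NS(=O)(=O)c1ccc(F)cc1` gives 7110 nM. Compound 2 `CC(C)N1C(=O)COc2ccc(-c3cnc(Cl)c(NS(=O)(=O)c4ccc(F)cc4)c3)cc21` gives 5380 nM, and these two values lie within the usual scatter of each other. Compound 3 `O=C1COc2ccc(-c3cnc(Cl)c(NS(=O)(=O)c4ccc(F)cc4)c3)cc2N1c1ccc(F)cc1` reads > 40000 nM, which is a limit of the assay and not a number. Compound 1 therefore stands level with compound 2, and only compound 3 sits at the limit.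

Compound 4 `COc1ccc(N2C(=O)COc3ccc(-c4cnc(OC)c(NS(=O)(=O)c5ccc(F)cc5)c4)cc32)cc1` keeps the core of compound 1 and changes one place: 4-methoxyphenyl in place of hydrogen on an amide-type nitrogen in a ring. That is 4-methoxyphenyl in place of hydrogen on an amide-type nitrogen in a ring.

Among the compounds with values here, one measured step bears on this change. Putting 4-fluorophenyl in place of isopropyl on an amide-type nitrogen in a ring gave an at least 7.4-fold higher number from compound 2 to compound 3 (0.87 log units; beyond the scatter), which is beyond the scatter. This is only a guide, since that step starts from isopropyl rather than hydrogen, and compound 2 and compound 3 also differ from compound 1 elsewhere on the core. From the compounds shown here alone, its end point is a limit, so its full size is unknown.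

Going by an at least 7.4-fold higher number from compound 2 to compound 3 (0.87 log units; beyond the scatter), a higher number, meaning a weaker inhibitor, is expected here. The expected change is a 2.8-fold higher number from compound 1 to compound 4 (0.45 log units; beyond the scatter). For compound 4 the estimated value is 20000 nM, with an expected range from 7000 nM to 60000 nM.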

Compound 4, half-maximal inhibitory concentration: 1220 nM
For compound 4 the middle estimate is 16-fold (1.21 log units) above the measured one; the measured number lies below the stated range.
By their numbers in this assay, from the lowest: compound 4; then compounds 2 and 1 (each within the scatter of the next). At a limit, above all of these: compound 3.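

In this assay, 4-methoxyphenyl in place of hydrogen on the amide-type nitrogen in a ring gives a 5.8-fold lower number from compound 1 to compound 4 (0.77 log units; beyond the scatter), so a phenyl ring carrying a substituent at this position can go with a stronger inhibitor on the core of compound 1. Within the data shown here, the only earlier step at this nitrogen, an at least 7.4-fold higher number from compound 2 to compound 3 (0.87 log units; beyond the scatter), pointed the other way, but it started from isopropyl rather than hydrogen, carried a different substituent on its phenyl ring and sat on a core that differs elsewhere, so a phenyl ring on this nitrogen does not by itself weaken the compounds, and compound 3 remains the case that goes against any simple gain. Compound 3 reads at a limit of the assay and not at a number: the limit of > 40000 nM in this assay, at which 1 of the 4 values shown sits.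

From the compounds shown here alone, what stays open is whether the gain belongs to the methoxy group or to the phenyl ring itself, a question that plain phenyl or 4-fluorophenyl on the core of compound 1 would address. Going by these compounds, it is also open how this nitrogen would respond to a small methyl group, a benzyl group or a longer chain ending in an amine.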